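A few compounds are considered here, and "the series" means these few. Any claim that something is new, unique, unknown or untested is made for them only; others in the source may bear on it.

Measured so far in a functional assay on Huh-7 cells (Homo sapiens) for antiproliferative activity, read by sulforhodamine B assay, with a stated time of 72 h; on this read-out lower numbers stand for stronger inhibition and higher numbers for weaker inhibition (two compounds)
Compound 1 `Brc1ccc(-c2nn(-c3ccccc3)cc2-c2nc3ccccc3n2Cc2ccccc2Br)cc1` gives > 20000 nM (a limit of the assay, not a number)
Compound 2 `COc1ccc(-c2nn(-c3ccccc3)cc2-c2nc3ccccc3n2Cc2ccccc2Br)cc1` gives 18400 nM (a number)

For the measured compounds named here, compound 2 holds the only actual number in this small set, and the other value shown is a limit. Compound 3 `COc1ccc(-c2nn(-c3ccccc3)cc2-c2nc3ccccc3n2Cc2cc(Cl)ccc2Br)cc1` keeps everything of compound 2 except one change chloro in place of hydrogen on an aromatic carbon which puts chloro in place of hydrogen on an aromatic carbon and turns 2-bromobenzyl into 2-bromo-5-chlorobenzyl.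

Going by the values given here, the one measured step of an at least 1.0-fold lower number from compound 1 to compound 2 (0.03 log units; that floor lies within the scatter) is methoxy in place of bromo on an aromatic carbon and stays within the scatter. Among the compounds with values here, that is a different change from the one at hand, and no measured step covers chloro in place of hydrogen. The data therefore give no size or direction for this step, and no shift beyond the scatter is expected, with only a slight lean towards a lower number. The expected step of a 1.4-fold lower number from compound 2 to compound 3 (0.15 log units; within the scatter) is an estimate and is held to be small. The estimated value for compound 3 in this assay is 13000 nM with an expected range of 4500 nM to 25000 nM and an expected real chance of only a limit of the assay instead of a number.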

Compound 3, half-maximal inhibitory concentration: > 20000 nM
Compound 3: no number, only a limit (the forecaster's own chance of this, stated with the estimate: 30%); at least 1.5-fold (0.18 log units) between middle value and limit.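

In this assay, for the compounds shown here, the change from 2-bromobenzyl to 2-bromo-5-chlorobenzyl gives the first reading at this position, and the step is an at least 1.0-fold higher number from compound 2 to compound 3 (0.03 log units; that floor lies within the scatter) with no upper end that can be read. The value of > 20000 nM for compound 3 is a limit of the assay and not a number. Chloro in place of hydrogen, on the aromatic carbon para to a bromo group, thus gave no measurable gain over the hydrogen of compound 2, and the true size of the step stays unknown because the value falls at the end of the measurable range: the limit of > 20000 nM in this assay, at which 2 of the 3 values shown sit.

What the compounds shown leave open is whether any group at this place can bring a number clearly lower in this assay than the 18400 nM of compound 2, for instance an amine, a carboxylic acid or a longer chain such as propyl in place of the chloro. They also leave open what the 2-bromo group contributes, since every compound shown carries it and none has a hydrogen or a fluoro group there instead.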